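An ethoxycarbonyl added to compound 3

The source may report more compounds than this note shows. Statements on the series, on what has been measured and on what is new or still open speak of the compounds shown alone.

For the measured compounds named here, in a functional assay (uterus) for inhibition, with Rattus norvegicus as the target (on this read-out higher numbers stand for an effect only at larger amounts of compound and lower numbers for an effect already at smaller amounts), three compounds have numbers so far. Compound 1 (`ClCc1cn2ccncc2n1`) gives 1.4 nM and compound 2 (`CCOC(=O)c1[nH]c2nccnc2c1C`) gives 0.102 nM there. Compound 3 (`Brc1cncc2nccn12`) gives 0.29 nM and so stands in the middle, clearly above compound 2 and clearly below compound 1. Compound 4 (`CCOC(=O)c1cn2c(Br)cncc2n1`) is compound 3 with one change: ethoxycarbonyl in place of hydrogen on an aromatic carbon of a five-membered aromatic ring with 2 nitrogen. Going by the values given here, no measured pair shows this change on its own. Compound 2 also carries an ethoxycarbonyl and gives 0.102 nM on a different core, which is only a weak hint toward a lower number. The expected step in this assay is a 1.5-fold lower number from compound 3 to compound 4 (0.16 log units; within the scatter) and so no move beyond the usual scatter, with a slight lean downward. The estimated value for compound 4 is 0.2 nM with a likely range of 0.04 nM to 1 nM in this estimate.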

Compound 4, concentration for half-maximal effect: 1.02 nM
Compound 4: the middle estimate sits 5.1-fold (0.71 log units) below what was measured, outside the stated range (above it).
By their numbers in this assay, from the lowest: compound 2; then compound 3; then compounds 4 and 1 (each within the scatter of the next).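

In this assay, ethoxycarbonyl in place of hydrogen on this aromatic carbon of the five-membered aromatic ring with 2 nitrogen gives a 3.5-fold higher number from compound 3 to compound 4 (0.55 log units; beyond the scatter) and so shows that this position responds to substitution, with this change moving the effect to larger amounts of compound. For the compounds shown here, this is the first step that can be read as a single change, but it rests on one pair and one core. Nothing at hand explains the shift.

As far as these compounds go, it remains open whether the whole ethoxycarbonyl matters or only a part of it, which a methyl, a carboxylic acid or an amide on the same carbon could help to separate. From the compounds shown here alone, whether the same change gives a similar step on another core also remains open.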